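The source may hold more compounds than are shown below. What is called first, only, known or untested is meant among the compounds shown, and "the series" means these compounds.

Working notes on the series. Compound 1 `CC(C)Cc1cnc(C(=O)/C=C/c2ccccc2O)cn1` gives 63000 nM in a functional assay on the whole organism for inhibition, with Chlorella vulgaris as the target, read by spectrophotometry, with a stated time of 4 h (on this read-out lower numbers stand for stronger inhibition and higher numbers for weaker inhibition), the lowest number among the three measured compounds. Compound 3 `CC(C)Cc1cnc(C(=O)/C=C/c2ccc(O)cc2)cn1` gives 232000 nM in this assay, and compound 2 `CCCc1cnc(C(=O)/C=C/c2ccc(O)cc2)cn1` gives 514000 nM. The step of a 3.7-fold higher number from compound 1 to compound 3 (0.57 log units; beyond the scatter) and the step of a 2.2-fold lower number from compound 2 to compound 3 (0.35 log units; beyond the scatter) are the two single-point changes measured so far.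

Compound 4 `CCCCc1cnc(C(=O)/C=C/c2ccccc2O)cn1` is not yet measured. It differs from compound 1 by propyl in place of isopropyl on a saturated chain carbon bound to an aromatic carbon. Going by the values given here, no measured step shows a branched chain rearranged to a straight chain of the same count; the nearest is the step from compound 2 to compound 3, which adds a methyl to the chain and, as noted, gives a modestly lower number. The move to compound 4 keeps the count but straightens the chain, so little guidance is available, and a step within the scatter or a modest rise in the number is expected.

For compound 4 the estimate in this assay is 90000 nM, with a range of 35000 nM to 230000 nM, which is expected to mean a step of a 1.4-fold higher number from compound 1 to compound 4 (0.15 log units; within the scatter).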

Compound 4, half-maximal inhibitory concentration: 147000 nM
Estimate against measurement, compound 4: 1.6-fold (0.21 log units) below, and the stated range covers the measured number.
By their numbers in this assay, from the lowest: compound 1; then compounds 4 and 3 (each within the scatter of the next); then compound 2.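

Going by these compounds alone, the change from isopropyl to propyl, read further out as isobutyl to butyl, gives a 2.3-fold higher number from compound 1 to compound 4 (0.37 log units; beyond the scatter) in this assay with the same atoms joined differently, so at this place the arrangement of the chain alone moves the number, which the earlier steps could not show. Together with a 2.2-fold lower number from compound 2 to compound 3 (0.35 log units; beyond the scatter), this puts the lower number with the isobutyl compound in both chain steps, with compound 1 on the 2-hydroxyphenyl side and compound 3 on the 4-hydroxyphenyl side, and neither step goes against this, although the step from compound 2 to compound 3 also changes the chain length. No measurement at hand accounts for either step.

Still open, going by these compounds, is how a longer chain such as hexyl, or a cyclohexyl ring, would read at this place. Also open, on these data alone, is whether butyl in place of isobutyl gives a step of similar size on the 4-hydroxyphenyl compounds.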